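One More Chloro on a Weak Inhibitor

The compounds below may be only part of what the source reports. "The series", "measured", "known", "first", "only" and "open" are said of these compounds alone.

Among the compounds with values here, in a functional assay on L02 cells (Homo sapiens) for inhibition, read by MTT assay, with a stated time of 72 h (a lower number here means a stronger inhibitor, a higher number a weaker inhibitor), compound 1 (`C=C(c1ccc(Cl)c(Cl)c1)C1COC2(CCCCC2)OO1`) gives 83500 nM, the only true number so far. Compound 2 (`C=C(c1ccc(OC)c(F)c1)C1COC(C)(C)OO1`) gives > 100000 nM, which is a limit of the assay and not a number. Compound 1 therefore sits at the weak end of the range, with little room left before that limit is reached, as the limit of > 100000 nM in this assay, at which 1 of the 2 values shown sits, shows.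

Compound 3 (`C=C(c1ccc(Cl)c(Cl)c1Cl)C1COC2(CCCCC2)OO1`) keeps the core of compound 1 and changes one place: chloro in place of hydrogen on an aromatic carbon. The new chloro stands ortho to a chloro group and ortho to a large group. Within the data shown here, no measured pair shows what such a swap does, so the expectation in this assay is for no change beyond the usual scatter. This estimate means an expected 1.1-fold lower number from compound 1 to compound 3 (0.05 log units; within the scatter). For compound 3 the expected value is 75000 nM, with an estimated range from 35000 nM to 100000 nM.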

Compound 3, half-maximal inhibitory concentration: 1220 nM
For compound 3 the middle estimate is 61-fold (1.79 log units) above the measured one; measured number outside the range, below it.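

This position on the aromatic ring, ortho to a chloro group and ortho to a large group, is not a silent one: in this assay, adding a single chloro gives a 68-fold lower number from compound 1 to compound 3 (1.84 log units; beyond the scatter). What enters is only one heavy atom, with no ring and no net charge, so a very small edit to the core of compound 1 is enough to matter here. It takes compound 3 well away from the weak end of the scale, where the assay stops giving numbers: the limit of > 100000 nM in this assay, at which 1 of the 3 values shown sits.

Only this one swap is shown at this place, so it remains open whether chloro itself matters or whether a methyl group, a nitrile or an amine there would do the same. The compounds shown also do not tell why the number falls so far.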